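Trading a Ring Methyl for Hydrogen: Expected Cytotoxicity

This account rests on a few compounds, and the source may have more. Where it says the series, first, only, none or still open, it means among the compounds named here.

Compound 1 `COc1ccc2c(OCC[C@@H]3NC(=O)N(C)CCCC/C=C\[C@@H]4C[C@@]4(C(=O)NS(=O)(=O)C4(C)CC4)NC3=O)cc(-c3nc(C(C)C)cs3)nc2c1F` was tested in an ADME assay on cells (Homo sapiens) for activation (on this read-out higher numbers stand for lower toxicity in this test and lower numbers for higher toxicity in this test), and gives 57100 nM. Among the two measured compounds it stands highest; its nearest neighbour is compound 2 `COc1ccc2c(OCC[C@@H]3NC(=O)N(C)CCCC/C=C\[C@@H]4C[C@@]4(C(=O)NS(=O)(=O)C4(C)CC4)NC3=O)cc(-c3nc(C(C)C)cs3)nc2c1Cl`, which in this assay gives 37400 nM. The step of a 1.5-fold lower number from compound 1 to compound 2 (0.18 log units; within the scatter), chloro in place of fluoro on an aromatic carbon, lies within the scatter. Compound 3 `COc1ccc2c(OCC[C@@H]3NC(=O)N(C)CCCC/C=C\[C@@H]4C[C@@]4(C(=O)NS(=O)(=O)C4CC4)NC3=O)cc(-c3nc(C(C)C)cs3)nc2c1F` differs from compound 1 at a different site: hydrogen in place of methyl on a saturated ring carbon, so that 1-methylcyclopropyl becomes cyclopropyl. For the measured compounds named here, no measured step touches this ring; the only measured step concerns a halogen swap elsewhere and stayed within the scatter. Compound 3 is therefore expected to sit close to compound 1, with an estimated step of a 1.0-fold lower number from compound 1 to compound 3 (0.02 log units; within the scatter) that should not exceed the scatter. Compound 3 is estimated in this assay at 55000 nM, within a range from 25000 nM to 120000 nM.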

Compound 3, half-maximal cytotoxic concentration: > 75000 nM
Compound 3: a limit, no number; the forecaster's own chance of this, stated with the estimate: 10%; middle value at least 1.3-fold (0.13 log units) from the limit.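

In this assay, compound 3 carries a limit of the assay and not a number: the limit of > 75000 nM in this assay, at which 1 of the 3 values shown sits. The change from 1-methylcyclopropyl to cyclopropyl gives an at least 1.3-fold higher number from compound 1 to compound 3 (0.11 log units; that floor lies within the scatter), so only a floor for this step is known, and how far the step reaches cannot be told. For the compounds shown here, until now no step had touched this three-membered ring, and this one shows that the methyl on its saturated ring carbon can go without any sign of higher toxicity in this test.

As far as these compounds go, it remains open whether a larger group on this ring carbon, such as ethyl or trifluoromethyl, would leave the read-out where it stands. The swap of fluoro for chloro is also shown only with 1-methylcyclopropyl, so its outcome with cyclopropyl is unknown.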